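A few compounds are considered here, and "the series" means these few. Any claim that something is new, unique, unknown or untested is made for them only; others in the source may bear on it.

In a functional assay on Jurkat cells (Homo sapiens) for inhibition, read by CCK-8 assay, with a stated time of 48 h (on this read-out lower numbers stand for stronger inhibition of growth and higher numbers for weaker inhibition of growth), compound 1 (`CN1CCN(c2ccc(Nc3ncc(Cl)c(NCc4ccccc4)n3)nc2)CC1`) gives > 100000 nM as a limit and not a number. Among the compounds with values here, compound 2 (`Cc1cc(C)c(Nc2nc(Nc3ccc(N4CCN(C)CC4)cn3)ncc2Cl)c(C)c1`) gives 7600 nM as the only actual number so far. Compound 3 (`COc1cccc(Nc2nc(Nc3ccc(N4CCN(C)CC4)cn3)ncc2Cl)c1`) differs from compound 2 thus: 3-methoxyphenyl in place of 2,4,6-trimethylphenyl on a nitrogen on an aromatic ring. Within the data shown here, one measured step bears on this place, and it is large: an at least 13-fold lower number from compound 1 to compound 2 (1.11 log units; beyond the scatter) (bounded by the limit of > 100000 nM in this assay, at which 1 of the 2 values shown sits). It shows that this place can move the number, but it compares no two phenyl groups. A modest move is therefore expected, estimated as a 2.5-fold lower number from compound 2 to compound 3 (0.40 log units; beyond the scatter) (toward stronger inhibition). Compound 3 is expected at 3000 nM with an estimated range from 500 nM to 20000 nM on this read-out.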

Compound 3, concentration for 50% growth inhibition: 15800 nM
Beside the measured number, compound 3's estimate is 5.3-fold (0.72 log units) below it; measured number inside the range.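

Within the data shown here, the first comparison of two phenyl groups at this position, on a nitrogen on an aromatic ring, shows a 2.1-fold higher number from compound 2 to compound 3 (0.32 log units; beyond the scatter) in this assay, so the choice of phenyl group itself moves the number, here toward weaker inhibition of growth. The 3-methoxyphenyl group still keeps an at least 6.3-fold lower number from compound 1 to compound 3 (0.80 log units; beyond the scatter), so both phenyl groups give lower numbers than the benzyl of compound 1. That second step is bounded by a limit, not a number: the limit of > 100000 nM in this assay, at which 1 of the 3 values shown sits.

The compounds shown do not separate the effect of the methoxy group from that of the three methyl groups. Also open, as far as these compounds go, is how an unsubstituted phenyl, or a phenyl carrying an amine or a carboxylic acid, would read at this position.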